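Dropping the aryl group from the amidine nitrogen

The compounds below may be only part of what the source reports. "The series", "measured", "known", "first", "only" and "open" are said of these compounds alone.

Measured compounds:
compound 1 `Cc1ccc(S(=O)(=O)/N=C(/CCNC2=CC(=O)c3ccccc3C2=O)Nc2ccc(F)cc2)cc1` — 5890 nM
compound 2 `Cc1ccc(S(=O)(=O)/N=C(/CCNC2=CC(=O)c3ccccc3C2=O)Nc2cccc(C(F)(F)F)c2)cc1` — 77600 nM
compound 3 `COc1cc(N/C(CCNC2=CC(=O)c3ccccc3C2=O)=N\S(=O)(=O)c2ccc(C)cc2)cc(OC)c1OC` — 3390 nM

In a functional assay on HeLa cells (Homo sapiens) for cytotoxicity, read by MTT assay, with a stated time of 48 h (on this read-out higher numbers stand for weaker inhibition and lower numbers for stronger inhibition), compound 3 gives the lowest of the three numbers. Its nearest neighbour differs only within the scatter: a 1.7-fold lower number from compound 1 to compound 3 (0.24 log units; within the scatter). The furthest lies well beyond it: a 23-fold lower number from compound 2 to compound 3 (1.36 log units; beyond the scatter). Compound 4 `Cc1ccc(S(=O)(=O)/N=C(\N)CCNC2=CC(=O)c3ccccc3C2=O)cc1` differs from compound 3 in one place: hydrogen in place of 3,4,5-trimethoxyphenyl on an amine nitrogen. Every measured step exchanges one aryl group for another on that nitrogen; none removes it. Those steps show the position can move the number a great deal, as in a 13-fold higher number from compound 1 to compound 2 (1.12 log units; beyond the scatter), or barely, as in a 1.7-fold lower number from compound 1 to compound 3 (0.24 log units; within the scatter). Nothing measured addresses a bare amidine, so the direction is uncertain; compound 4 is estimated to give a higher number, 20000 nM (range 4000 nM to 100000 nM). The expected step is a 5.9-fold higher number from compound 3 to compound 4 (0.77 log units; beyond the scatter).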

Compound 4, half-maximal inhibitory concentration: 24600 nM
The estimate for compound 4 lay 1.2-fold (0.09 log units) below the measured number; measured number inside the range.
By their numbers in this assay, from the lowest: compounds 3 and 1 (each within the scatter of the next); then compound 4; then compound 2.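

In this assay taking the aryl group off the amine nitrogen has no single direction: the change gives a 7.3-fold higher number from compound 3 to compound 4 (0.86 log units; beyond the scatter) and a 4.2-fold higher number from compound 1 to compound 4 (0.62 log units; beyond the scatter) but a 3.2-fold lower number from compound 2 to compound 4 (0.50 log units; beyond the scatter). Hydrogen therefore falls inside the span of the aryl groups, with 3,4,5-trimethoxyphenyl and 4-fluorophenyl on its lower side and 3-(trifluoromethyl)phenyl on its higher side. No measurement at hand accounts for this reversal. As far as these compounds go, whether a methyl or a benzyl group on that nitrogen would fall nearer hydrogen or the aryl groups stays open.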